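This account rests on a few compounds, and the source may have more. Where it says the series, first, only, none or still open, it means among the compounds named here.

Measured so far in an ADME assay on L6 cells (Rattus norvegicus) for cytotoxicity, read by resazurin assay, with a stated time of 70 h; on this read-out lower numbers stand for stronger inhibition and higher numbers for weaker inhibition:
Compound 1, `N=C(N)c1ccc2oc(-c3ccc(OCCCCOc4ccccc4)cc3)cc2c1`: 1300 nM
Compound 2, `c1ccc(OCCCCOc2ccc(-c3cc4cc(C5=NCCN5)ccc4o3)cc2)cc1`: 2900 nM

Compound 1 stands at the lower of the two numbers in this assay, which here means the stronger effect on the cells. For the measured compounds named here, the only measured step is the one from compound 1 to compound 2: a 2.2-fold higher number from compound 1 to compound 2 (0.35 log units; beyond the scatter). That step alters the group on the aromatic ring at one end of the molecule and says nothing about the chain that links the two outer rings.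

Compound 3, `N=C(N)c1ccc2oc(-c3ccc(OCCCCCCOc4ccccc4)cc3)cc2c1`, is not yet measured. It differs from compound 1 in that chain: 2-phenoxyethyl in place of phenoxy on a saturated chain carbon, four bonds along the chain from an oxygen on an aromatic ring. Going by the values given here, no measured step bears on this kind of change, so no step beyond the scatter is expected in this assay. The step of no change at the digits printed from compound 1 to compound 3 (within the scatter) is therefore estimated to stay within the scatter. Compound 3 is expected to give 1300 nM, with a range from 600 nM to 3000 nM.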

Compound 3, half-maximal inhibitory concentration: 3300 nM
Estimate against measurement, compound 3: 2.5-fold (0.40 log units) below; measured number above the stated range.
By their numbers in this assay, from the lowest: compound 1; then compounds 2 and 3 (each within the scatter of the next).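

In this assay the chain linking the two outer rings is not a silent place: 2-phenoxyethyl in place of phenoxy gives a 2.5-fold higher number from compound 1 to compound 3 (0.40 log units; beyond the scatter), which means a weaker effect on the cells. For the compounds shown here, this is the first measured change in the chain, and it shows that the number responds to the chain as well as to the group altered in compound 2. Nothing available here explains the rise.

As far as these compounds go, with only this one lengthening, it remains open whether a still longer chain would raise the number further or a shorter chain would lower it. From the compounds shown here alone, it is also open whether an amine built into the chain would change the number, and whether the same lengthening would have a similar effect on compound 2.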